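This account rests on a few compounds, and the source may have more. Where it says the series, first, only, none or still open, it means among the compounds named here.

Compound 1 `Cc1ccc(-c2cnn3c(NCc4ccccn4)cc(C)nc23)cc1`: < 5000 nM
Compound 2 `Cc1cc(NCc2cccnc2)n2nc(C)c(-c3ccccc3)c2n1`: 110000 nM
Compound 3 `Cc1cc(NCc2ccncc2)n2nc(C)c(-c3ccccc3)c2n1`: 134000 nM

All three were measured in a physicochemical assay for solubility, read by HPLC, using the shake flask method, measured as kinetic solubility, with a stated time of 2 h, at pH 7.4; a higher number here means a more soluble compound, a lower number a less soluble compound. In this assay compound 1 gives < 5000 nM, which is a limit of the assay and not a number. Compound 2 gives 110000 nM. Compound 3 gives 134000 nM, the larger of the two numbers, though its gap to compound 2 is within the scatter a 1.2-fold higher number from compound 2 to compound 3 (0.09 log units; within the scatter). That single measured step, pyridin-4-yl in place of pyridin-3-yl on a saturated chain carbon bound to a nitrogen on an aromatic ring, is the only one available, and it is small.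

Compound 4 `Cc1cc(NCc2cnccn2)n2nc(C)c(-c3ccccc3)c2n1` differs from compound 3 by pyrazin-2-yl in place of pyridin-4-yl on a saturated chain carbon bound to a nitrogen on an aromatic ring. The step from compound 2 to compound 3 bears on this only loosely: it exchanged one pyridinyl for another, whereas the change to compound 4 brings in pyrazin-2-yl, a ring with two hetero atoms. Among the compounds with values here, no measured compound carries such a ring, so the data give no direct guide. On the one step shown, the step of a 1.0-fold lower number from compound 3 to compound 4 (0.01 log units; within the scatter) is expected to stay within the scatter. Compound 4 is therefore estimated at 130000 nM, with a range from 55000 nM to 300000 nM.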

Compound 4, solubility: 7100 nM
The estimate for compound 4 lay 18-fold (1.26 log units) above the measured number; the measured number lies below the stated range.
By their numbers in this assay, from the lowest: compound 4; then compounds 2 and 3 (each within the scatter of the next). At a limit, below all of these: compound 1.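

Within the data shown here, at this place, on a saturated chain carbon bound to a nitrogen on an aromatic ring, the earlier compounds showed only that pyridin-4-yl in place of pyridin-3-yl stays within the scatter, whereas the ring itself now proves to matter in this assay, with pyrazin-2-yl in place of pyridin-4-yl giving a 19-fold lower number from compound 3 to compound 4 (1.28 log units; beyond the scatter). The same exchange starting from pyridin-3-yl gives a 15-fold lower number from compound 2 to compound 4 (1.19 log units; beyond the scatter), so the large step appears whichever of the two pyridinyl groups leaves. The entering ring has the same number of heavy atoms as the leaving ones and differs by one ring carbon exchanged for a nitrogen, so a small change in the ring is enough for a large step, and compound 4 still gives a number, with a limit of the assay not far off: the limit of < 5000 nM in this assay, at which 1 of the 4 values shown sits.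

On these data alone, whether this step belongs to pyrazin-2-yl alone or would also come with a pyrimidinyl ring remains open, as does what a plain phenyl ring or a morpholine would give at this place. Compound 1 differs from the others in more than one place and its value is a limit, so it offers no comparison here.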